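Swapping the aryl ring in compound 3: what to expect

This account rests on a few compounds, and the source may have more. Where it says the series, first, only, none or still open, it means among the compounds named here.

Compound 1, `CCCS(=O)(=O)Nc1ccc(F)c(C(=O)c2n[nH]c3ncc(-c4ccc(Cl)cc4Cl)cc23)c1F`, in an assay for binding affinity to dual specificity mitogen-activated protein kinase kinase 4 (Homo sapiens), read by KINOMEscan, tested at 100 nM (a lower number here means a stronger effect, a higher number a weaker effect of the compound at the concentration tested), gives 22%.
Compound 2, `CCCS(=O)(=O)Nc1ccc(F)c(C(=O)c2n[nH]c3ncc(-c4cc(Cl)cc(Cl)c4)cc23)c1F`, in this assay gives 73%.
Compound 3, `CCCS(=O)(=O)Nc1ccc(F)c(C(=O)c2n[nH]c3ncc(-c4ccc(Cl)c(C(F)(F)F)c4)cc23)c1F`, in this assay gives 15%.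

All three share one core and differ only in the aryl ring attached to it. Compound 3 stands at the lowest number of the three, with compound 1 nearest (a number 7 percentage points lower from compound 1 to compound 3 (within the scatter)) and compound 2 furthest (a number 58 percentage points lower from compound 2 to compound 3 (beyond the scatter)). Compound 4 is `CCCS(=O)(=O)Nc1ccc(F)c(C(=O)c2n[nH]c3ncc(-c4ccc(F)cc4C)cc23)c1F`, not yet measured. 4-fluoro-2-methylphenyl in place of 4-chloro-3-(trifluoromethyl)phenyl on an aromatic carbon The two steps already seen show that this ring matters: the 2,4-dichlorophenyl and the 4-chloro-3-(trifluoromethyl)phenyl sit close together, while the 3,5-dichlorophenyl is far weaker. The 4-fluoro-2-methylphenyl of compound 4 carries its groups at positions numbered like those of the 2,4-dichlorophenyl of compound 1, so the outcome is expected to stay nearer compound 1 and compound 3 than compound 2, allowing for a modest rise in the number. The estimated step is a number 15 percentage points higher from compound 3 to compound 4 (beyond the scatter). Compound 4 is therefore expected to give 30% in this assay, within 10% to 60%.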

Compound 4, a percentage reported as activity, at one concentration (the size of the read-out at that concentration, not a potency): 14%
Compound 4: the middle estimate sits 16 percentage points above what was measured; low and high end bracket the measured number.
By their numbers in this assay, from the lowest: compounds 4, 3 and 1 (each within the scatter of the next); then compound 2.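

In this assay this position does not need a chlorine: all three earlier rings carried one, while the 4-fluoro-2-methylphenyl of compound 4 has none, and the swaps read as a number 1 percentage points lower from compound 3 to compound 4 (within the scatter) and a number 8 percentage points lower from compound 1 to compound 4 (within the scatter) with no real shift. The entering ring has fewer heavy atoms than the ring that leaves, so a ring with fewer heavy atoms and no trifluoromethyl also fits this low group. The 3,5-dichlorophenyl stays the exception, with a number 59 percentage points lower from compound 2 to compound 4 (beyond the scatter) as the new measure of that gap, and nothing shown explains why.

Open, going by these compounds, is how a ring carrying an amine or a carboxylic acid would read at this position. Also open, on these data alone, is whether a plain phenyl ring, with no groups on it, would stay with compound 1, compound 3 and compound 4.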